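The compounds below may be only part of what the source reports. "The series", "measured", "known", "first", "only" and "open" are said of these compounds alone.

Measured in an ADME assay on HepG2 cells (Homo sapiens) for cytotoxicity, with a stated time of 72 h; a lower number here means that less compound is needed, a higher number that more compound is needed for the effect:
compound 1 `Cc1cc(NC(=O)Nc2ccc(C(C)(C)C)cc2)c2ccccc2n1`: 17000 nM
compound 2 `Cc1cc(NC(=O)Nc2ccc(C)c(Cl)c2)c2ccccc2n1`: > 25000 nM (a limit of the assay, not a number)
compound 3 `Cc1cc(NC(=O)Nc2ccccc2OC(F)(F)F)c2ccccc2n1`: > 25000 nM (a limit of the assay, not a number)

Among these three ureas, compound 1 is the only one that gives a true number, at 17000 nM. The other two values are limits, and the series is marked by the limit of > 25000 nM in this assay, at which 2 of the 3 values shown sit. How far compound 2 and compound 3 lie from compound 1 therefore cannot be read from these data.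

The next compound to be tested is compound 4 `CSc1ccc(NC(=O)Nc2cc(C)nc3ccccc23)cc1`, which keeps the core of compound 1 and changes one substituent. Methylsulfanyl stands in place of tert-butyl on an aromatic carbon of a six-membered aromatic ring of carbon only, para to a large group: methylsulfanyl in place of tert-butyl on an aromatic carbon.

Going by the values given here, no measured pair isolates a change of this kind, so the expectation rests on the overall spread alone. With compound 1 at 17000 nM and the rest of the series at the limit of > 25000 nM in this assay, at which 2 of the 3 values shown sit, no step beyond the usual scatter is expected, with a slight lean towards a higher number. The expected change is a 1.3-fold higher number from compound 1 to compound 4 (0.11 log units; within the scatter). The estimated value for compound 4 is 22000 nM, with an expected range from 11000 nM to 40000 nM.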

Compound 4, half-maximal effective concentration: 16000 nM
Compound 4: the middle estimate sits 1.4-fold (0.14 log units) above what was measured; low and high end bracket the measured number.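

In this assay, placing methylsulfanyl in place of tert-butyl on an aromatic carbon, para to a large group, gives a 1.1-fold lower number from compound 1 to compound 4 (0.03 log units; within the scatter). Going by these compounds alone, this is the first pair that differs in one place and can be read as a step, and it shows that at this position the two groups cannot be told apart in this assay, even though methylsulfanyl brings fewer heavy atoms, a sulfur and a hydrogen-bond acceptor in place of the all-carbon tert-butyl. The series now holds two true numbers, but it is still marked by a limit of the assay, which is not a number: the limit of > 25000 nM in this assay, at which 2 of the 4 values shown sit.

Whether this position would read the same with an amine, a carboxylic acid or a longer chain in place of tert-butyl remains open, since the single step shown covers only methylsulfanyl. Steps that involve compound 2 or compound 3 cannot be read, so how either of them stands relative to the two true numbers remains unknown.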